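The source may hold more compounds than are shown below. What is called first, only, known or untested is meant among the compounds shown, and "the series" means these compounds.

In an ADME assay on TZM cells (Homo sapiens) for cytotoxicity, read by XTT assay, with a stated time of 4 days (on this read-out lower numbers stand for higher toxicity in this test and higher numbers for lower toxicity in this test), compound 1 `CNC(=O)c1cc2ncn(-c3ccc(C#N)cc3)c2cc1Oc1c(C)cc(/C=C/C#N)cc1C` gives > 890000 nM, which is a limit and not a number. Compound 2 `Cc1cc(/C=C/C#N)cc(C)c1Oc1cc(Nc2ccc(C#N)cc2)c(N)cc1C(N)=O` gives > 23600 nM, again a limit. Within the data shown here, compound 3 `Cc1cc(C#N)cc(C)c1Oc1cc(Nc2ccc(C#N)cc2)c(N)cc1C(F)(F)F` gives 13300 nM, the only exact number among the three. Compound 2 therefore has no exact position on this scale, and its true value could lie anywhere beyond its limit. Compound 4 `Cc1cc(/C=C/C#N)cc(C)c1Oc1cc(Nc2ccc(C#N)cc2)c(N)cc1C(=O)O` differs from compound 2 in one place: hydroxy in place of amino on a carbonyl carbon. This puts hydroxy in place of amino on a carbonyl carbon, which reads as carbamoyl to carboxy. Among the measured compounds shown here, no measured pair shows this change directly, so only a small shift towards lower toxicity is expected. The expected change is a step that the limit leaves unreadable from compound 2 to compound 4. For compound 4, the estimated value is 40000 nM, with an expected range of 15000 nM to 150000 nM.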

Compound 4, half-maximal cytotoxic concentration: 14900 nM
Estimate against measurement, compound 4: 2.7-fold (0.43 log units) above, and the stated range ends above it.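

In this assay, hydroxy in place of amino on a carbonyl carbon, which reads as carbamoyl to carboxy, gives an at least 1.5-fold lower number from compound 2 to compound 4 (0.19 log units; that floor lies within the scatter). This is the first step shown for any change at this place, and since its floor lies within the usual scatter, it does not yet establish a real difference. The true size stays unknown because compound 2 has a limit and not a number: the limit of > 23600 nM in this assay, at which 1 of the 4 values shown sits.

As far as these compounds go, whether a methyl ester or an ethyl ester on this carbonyl carbon would give a different number remains open. So does whether the same swap would have a similar effect on the core of compound 1.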